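A few compounds are considered here, and "the series" means these few. Any claim that something is new, unique, unknown or untested is made for them only; others in the source may bear on it.

Three pyrazoline amides were tested in a functional assay on MGC-803 cells (Homo sapiens) for cytotoxicity, read by MTT assay, with a stated time of 48 h (a lower number here means a stronger inhibitor, a higher number a weaker inhibitor), and a fourth awaits its measurement. Compound 1 `CCC(=O)N1N=C(C)CC1c1cc(Br)cc(Br)c1O` carries a propanoyl group on the ring nitrogen and a dibromo-hydroxyphenyl group on the ring carbon; in this assay compound 1 gives 38600 nM. Compound 2 `CC1=NN(C(=O)c2ccc(C)cc2)C(c2cc(Br)cc(Br)c2O)C1` keeps the same core but bears a (4-methylphenyl)carbonyl group instead; in this assay compound 2 gives 56500 nM. The change from compound 2 to compound 1 is ethyl in place of 4-methylphenyl on a carbonyl carbon, and it made a step of a 1.5-fold lower number from compound 2 to compound 1 (0.17 log units; within the scatter), so the two numbers cannot be told apart.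

Compound 3 `Cc1ccc(C(=O)N2N=C(c3cc4ccccc4oc3=O)CC2c2ccccc2)cc1` has a different core, with a coumarin ring and a phenyl ring on the pyrazoline; in this assay compound 3 gives 31300 nM. The difference between the core of compound 3 and the core of compound 2 is not broken down here. All three measured numbers sit within the usual scatter of one another.

Compound 4 `CCC(=O)N1N=C(c2cc3ccccc3oc2=O)CC1c1ccccc1` is the not-yet-measured partner of compound 3: the change is ethyl in place of 4-methylphenyl on a carbonyl carbon, the same change as that from compound 2 to compound 1, at the same kind of place. Because the earlier step of a 1.5-fold lower number from compound 2 to compound 1 (0.17 log units; within the scatter) stayed within the scatter, the step from compound 3 to compound 4 is expected to be small as well, at about a 1.3-fold lower number from compound 3 to compound 4 (0.10 log units; within the scatter). Compound 4 is therefore estimated to give roughly 25000 nM in this assay, most likely between 10000 nM and 60000 nM.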

Compound 4, half-maximal inhibitory concentration: 5300 nM
Compound 4: the middle estimate sits 4.7-fold (0.67 log units) above what was measured, and the stated range ends above it.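

In this assay, putting ethyl in place of 4-methylphenyl on the carbonyl carbon of the core of compound 3 gives a 5.9-fold lower number from compound 3 to compound 4 (0.77 log units; beyond the scatter), a real change rather than scatter. The same change therefore does not carry over at the same size from one core to the other, and its effect on one core would have been a poor guide to its effect on the other: the same change on two cores in this assay, a 1.5-fold lower number (0.17 log units; within the scatter) from compound 2 to compound 1 and a 5.9-fold lower number (0.77 log units; beyond the scatter) from compound 3 to compound 4, 4.0-fold (0.61 log units) apart, beyond the scatter of two such steps This shows that the size of the step depends on the core for these two pairs, but it does not show which part of the core matters, as the two cores differ in more than one place, and two pairs give no rule for any further core.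

The compounds shown leave open how the number moves on the core of compound 3 with other groups on the same carbonyl carbon, such as a longer chain like butyl or a plain phenyl ring. They also leave open whether a chain ending in an amine or a carboxylic acid would follow ethyl or 4-methylphenyl, and whether the gap between the two cores would persist with those groups.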